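The source may hold more compounds than are shown below. What is called first, only, known or untested is meant among the compounds shown, and "the series" means these compounds.

Going by the values given here, compound 1 `COc1cccc(NC(=O)/C=C/c2coc3cc(OC)ccc3c2=O)c1` shows the higher of the two numbers so far in an ADME assay on HepG2 2.2.15 cells (Homo sapiens) for cytotoxicity, read by MTT assay, with stated times of 48 h and 9 days; a lower number here means that less compound is tolerated, a higher number that more compound is tolerated: compound 1 gives 1130000 nM, whereas compound 2 `Cc1ccc(CNC(=O)/C=C/c2coc3cc(O)ccc3c2=O)cc1` gives 501000 nM in this assay , a gap beyond the scatter. No single-point comparison between measured compounds is available. Compound 3 `COc1ccc2c(=O)c(/C=C/C(=O)Nc3ccc(Cl)cc3)coc2c1` differs from compound 1 by 4-chlorophenyl in place of 3-methoxyphenyl on an amide-type nitrogen. Among the compounds with values here, with no matched step to lean on, the expected change from compound 1 to compound 3 in this assay is a 1.4-fold lower number from compound 1 to compound 3 (0.15 log units; within the scatter), small and not clearly beyond the scatter. Compound 3 is therefore estimated at 800000 nM in this assay , in the range 300000 nM to 2000000 nM.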

Compound 3, half-maximal cytotoxic concentration: 272000 nM
Compound 3: middle estimate off by 2.9-fold (0.47 log units), on the high side; the whole stated range lies above it.
By their numbers in this assay, from the lowest: compounds 3 and 2 (each within the scatter of the next); then compound 1.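

On an amide-type nitrogen, 4-chlorophenyl in place of 3-methoxyphenyl gives a 4.2-fold lower number from compound 1 to compound 3 (0.62 log units; beyond the scatter) in this assay. This first matched step shows that, with the core of compound 1 held fixed, the aryl group at this position can shift the number beyond the scatter. No evidence available here accounts for the step.

The compounds shown do not separate the identity of the substituent from its place on the phenyl ring, which 3-chlorophenyl or 4-methoxyphenyl would address. On these data alone, how an amine or a carboxylic acid on this phenyl ring would read in this assay also remains open.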